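The source may hold more compounds than are shown below. What is called first, only, known or untested is meant among the compounds shown, and "the series" means these compounds.

Compound 1 `CCCC(C)Nc1nc(C)nc2c1nnn2-c1c(C)cc(C)cc1C` and compound 2 `COCC(COC)Nc1nc(C)nc2c1nnn2-c1ccc(C(C)C)cc1Br` share one core. In an in vitro assay on 293-EBNA cells for binding affinity to corticotropin-releasing factor receptor 1 (Homo sapiens) (on this read-out higher numbers stand for weaker inhibition and lower numbers for stronger inhibition), compound 1 gives 7.1 nM, and compound 2 gives 10.3 nM; the two numbers lie within the scatter of each other, so no order between them is claimed. Compound 3 `CCN(c1nc(C)nc2c1nnn2-c1ccc(C(C)C)cc1Br)C(COC)COC` is compound 2 with ethyl in place of hydrogen on a nitrogen on an aromatic ring. Nothing measured in the series covers this kind of change, so only an expectation can be given. From compound 2 to compound 3 a step of a 1.9-fold lower number from compound 2 to compound 3 (0.27 log units; within the scatter) is expected, no larger than the scatter, if anything toward lower numbers. For compound 3 a value of 5.5 nM is estimated, within 1.5 nM to 20 nM.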

Compound 3, inhibition constant: 123 nM
Compound 3: the middle estimate sits 22-fold (1.35 log units) below what was measured; measured number outside the range, above it.
By their numbers in this assay, from the lowest: compounds 1 and 2 (each within the scatter of the next); then compound 3.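

In this assay, ethyl in place of hydrogen on a nitrogen on an aromatic ring gives a large change (a 12-fold higher number from compound 2 to compound 3 (1.08 log units; beyond the scatter)), so this position does not tolerate every substitution. Going by these compounds alone, this is the first single-place step, and compound 1 and compound 2, which differ in more than one place, could not show it. No measurement at hand bears on the cause of this step. Going by these compounds, whether methyl or a longer chain such as propyl on this nitrogen behaves like ethyl remains open. Also open, on these data alone, is whether ethyl on the same nitrogen of compound 1 gives a comparable step.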